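From Amide to Urea on a Shared Core

This account rests on a few compounds, and the source may have more. Where it says the series, first, only, none or still open, it means among the compounds named here.

Compound 1 `COc1cc(Cl)cc(-c2nn(-c3cccc(NC(=O)c4ccc(Cl)c(Cl)c4)c3)cc2-c2ccncc2)c1` and compound 2 `O=C(Nc1cccc(-n2cc(-c3ccncc3)c(-c3cc(O)cc(Cl)c3)n2)c1)Nc1ccc(Cl)c(Cl)c1` have both been examined in a functional assay on KM12 cells (Homo sapiens) for inhibition, read by sulforhodamine B assay, with a stated time of 48 h, tested at 10 uM; on this read-out higher numbers stand for a weaker effect at the one concentration tested and lower numbers for a stronger effect. In this assay compound 1 gives 62.3%, the highest of the two numbers on hand. In this assay compound 2 gives 2.26%, a far lower number, and the gap between the two lies beyond the usual scatter of such measurements.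

Compound 3 `COc1cc(Cl)cc(-c2nn(-c3cccc(NC(=O)Nc4ccc(Cl)c(Cl)c4)c3)cc2-c2ccncc2)c1` has not yet been measured. It differs from compound 1 in one place: (3,4-dichlorophenyl)amino in place of 3,4-dichlorophenyl on a carbonyl carbon. Among the measured compounds shown here, no pair of measured compounds differs in exactly this way, so the size of the step can only be expected, not read off. Compound 2 also carries a ((3,4-dichlorophenyl)carbamoyl)amino group and gives the far lower number, though it differs from compound 3 in a further respect as well. On that basis the step from compound 1 to compound 3 is expected to be a sizeable fall in the number, a number 42.3 percentage points lower from compound 1 to compound 3 (beyond the scatter), well beyond the scatter. Compound 3 is accordingly estimated to give 20% in this assay, with a plausible range from 3% to 50%.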

Compound 3, a percentage reported as activity, at one concentration (the size of the read-out at that concentration, not a potency): 14.4%
For compound 3 the middle estimate is 5.6 percentage points above the measured one; the range from low to high includes it.
By their numbers in this assay, from the lowest: compound 2; then compound 3; then compound 1.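

In this assay the change from amide to urea can now be read on its own: with (3,4-dichlorophenyl)amino in place of 3,4-dichlorophenyl on a carbonyl carbon, the shared core shows a number 47.9 percentage points lower from compound 1 to compound 3 (beyond the scatter) and thus a much stronger effect at the one concentration tested. A second single change can also be read, with methyl in place of hydrogen on an oxygen on an aromatic ring, and it shows a number 12.1 percentage points higher from compound 2 to compound 3 (beyond the scatter) as a modest step, still beyond the scatter, while the step on the carbonyl carbon is a large one. Nothing on hand explains either step.

The compounds shown leave open whether the step on the carbonyl carbon keeps its size when hydrogen rather than methyl sits on that oxygen, since no amide with hydrogen there is among them. They also leave open how a simple alkylamino group or a longer chain on the carbonyl carbon, or an amine or a carboxylic acid on that oxygen-bearing aromatic ring, would read in this assay and how these single-concentration readings relate to potency.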